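Moving the chlorine around the sulfonyl-bound phenyl ring

This account rests on a few compounds, and the source may have more. Where it says the series, first, only, none or still open, it means among the compounds named here.

Three compounds share one core and differ only in the ring attached to the sulfonyl sulfur. Compound 3 `O=C(NCc1ccc(CNS(=O)(=O)c2ccc(F)c(F)c2)cc1)c1ccc(F)cc1` carries a 3,4-difluorophenyl there and in an assay on MDA-MB-231 cells for binding affinity to C-X-C chemokine receptor type 4 (Homo sapiens), read by fluorescence and microscopy, with stated times of 10 min and 30 min (a lower number here means that less compound is needed, a higher number that more compound is needed for the effect), compound 3 gives 10 nM. That places compound 3 second highest of the three numbers: compound 2 `O=C(NCc1ccc(CNS(=O)(=O)c2ccc(F)cc2)cc1)c1ccc(F)cc1`, with a 4-fluorophenyl, gives 1 nM in this assay, and the step of a 10-fold higher number from compound 2 to compound 3 (1.00 log units; beyond the scatter) is modest. Compound 1 `O=C(NCc1ccc(CNS(=O)(=O)c2ccccc2Cl)cc1)c1ccc(F)cc1`, with a 2-chlorophenyl, gives 1000 nM in this assay, far above both, as the steps of a 1000-fold lower number from compound 1 to compound 2 (3.00 log units; beyond the scatter) and a 100-fold lower number from compound 1 to compound 3 (2.00 log units; beyond the scatter) show.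

Compound 4 `O=C(NCc1ccc(CNS(=O)(=O)c2cccc(Cl)c2)cc1)c1ccc(F)cc1` changes (3-chlorophenyl in place of 3,4-difluorophenyl on a sulfonyl sulfur). Among the compounds with values here, no measured step matches this exactly. Within the data shown here, the only measured compound carrying chlorine on this ring, compound 1, gave the highest number, while both fluorine-bearing rings gave low numbers, which argues for a number above that of compound 3. Compound 4 is therefore expected to give 30 nM in this assay, within a range from 3 nM to 300 nM, meaning an expected step of a 3.0-fold higher number from compound 3 to compound 4 (0.48 log units; beyond the scatter).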

Compound 4, effective concentration (reported as EC, without a stated level of effect): 1 nM
Compound 4: the middle estimate sits 30-fold (1.48 log units) above what was measured; measured number outside the range, below it.
By their numbers in this assay, from the lowest: compounds 2 and 4 (each within the scatter of the next); then compound 3; then compound 1.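

Chlorine on this ring does not by itself bring a high number in this assay: 3-chlorophenyl in place of 2-chlorophenyl on the sulfonyl sulfur gives a 1000-fold lower number from compound 1 to compound 4 (3.00 log units; beyond the scatter), so the two chlorine-bearing rings lie far apart. The 3-chlorophenyl ring also matches the 4-fluorophenyl ring, with no change at the digits printed from compound 2 to compound 4 (within the scatter), and it improves on the 3,4-difluorophenyl ring, with a 10-fold lower number from compound 3 to compound 4 (1.00 log units; beyond the scatter), so a ring with a single halogen can give a low number whether that halogen is chlorine or fluorine, while compound 1 goes against this. No measurement shown here explains these differences.

Still open, as far as these compounds go, is how a 4-chlorophenyl or an unsubstituted phenyl ring would behave on the sulfonyl sulfur. Also open, from the compounds shown here alone, is whether this ring would tolerate a methoxy group, an amine or a carboxylic acid in place of halogen.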